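The compounds below may be only part of what the source reports. "The series", "measured", "known", "first", "only" and "open" are said of these compounds alone.

Compound 1 `Cc1ccc(S(=O)(=O)Oc2ccc3c(c2C)[C@H](Cn2cc(-c4ccccc4)nn2)[C@@]24CC(=O)[C@@](C)(CC[C@@H]32)C4)cc1`: in a functional assay on HL-60 cells (Homo sapiens) for cytotoxicity, read by MTT assay, with a stated time of 4 days (a higher number here means a weaker inhibitor, a lower number a stronger inhibitor), compound 1 gives > 20000 nM, which is a limit of the assay and not a number.
Compound 2 `Cc1ccc(S(=O)(=O)Oc2ccc3c(c2C)[C@H](Cn2cc(-c4ccccn4)nn2)[C@@]24CC(=O)[C@@](C)(CC[C@@H]32)C4)cc1`: in this assay compound 2 gives > 20000 nM, again a limit.
Compound 3 `C=C1C[C@]23C[C@@]1(O)CC[C@@H]2c1cccc(C)c1[C@@H]3Cn1cc(-c2ccccn2)nn1`: in this assay compound 3 gives > 20000 nM, also a limit.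

All three measured values therefore sit at one and the same limit (the limit of > 20000 nM in this assay, at which 3 of the 3 values shown sit). Compound 1 and compound 2 share a core and differ in a single place (phenyl in place of pyridin-2-yl on an aromatic carbon). The step that the two limits leave unreadable from compound 2 to compound 1 cannot be given a size because both of its values rest at the limit (the limit of > 20000 nM in this assay, at which 3 of the 3 values shown sit). The difference between the core of compound 3 and the core of compound 2 is not broken down here.

Compound 4 `C=C1C[C@]23C[C@@]1(O)CC[C@@H]2c1cccc(C)c1[C@@H]3Cn1cc(-c2ccccc2)nn1` has not yet been measured. It arises from compound 3 by phenyl in place of pyridin-2-yl on an aromatic carbon, the same change, at the same place, as between compound 2 and compound 1. Since that change left both of those compounds at the limit, and since compound 3 itself gives only a limit, the expected step is a step that the limit leaves unreadable from compound 3 to compound 4, that is, no readable change. Compound 4 is accordingly estimated at 30000 nM, most probably reported once more only as a limit.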

Compound 4, half-maximal inhibitory concentration: > 20000 nM
Compound 4: no number, only a limit; the forecaster's own chance of this, stated with the estimate: 85%; the middle value is on the limit's open side.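

No size can be given for the change from compound 3 to compound 4, because both values rest at the same limit and neither is a number: the limit of > 20000 nM in this assay, at which 4 of the 4 values shown sit.

The compounds shown leave open how strongly any of them acts in this assay, and whether phenyl in place of pyridin-2-yl makes any difference there.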